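The compounds below may be only part of what the source reports. "The series", "measured", "known", "first", "only" and "open" are said of these compounds alone.

In a functional assay on A2780 cells (Homo sapiens) for antiproliferative activity, read by fluorescence, with a stated time of 72 h (a higher number here means a weaker inhibitor, a lower number a stronger inhibitor), compound 1 (`CN1CCC(C(=O)N2Cc3c(NC(=O)C4CCC4)n[nH]c3C2(C)C)CC1`) gives 140 nM. Going by the values given here, compound 2 (`CC(C)(C)C(=O)N1Cc2c(NC(=O)c3ccc(F)cc3)n[nH]c2C1(C)C`) gives 270 nM, within the scatter of compound 1, so these two share the low end of the numbers so far. Compound 3 (`CN(C)CC(=O)Nc1n[nH]c2c1CN(C(=O)C(C)(C)C)C2(C)C`) gives 580 nM, a higher number than compound 1 and beyond the scatter.

Compound 4 (`CN1CCC(C(=O)N2Cc3c(NC(=O)c4ccco4)n[nH]c3C2(C)C)CC1`) has not yet been measured. Among the compounds with values here, it has furan-2-yl in place of cyclobutyl on a carbonyl carbon, its only change from compound 1 (furan-2-yl in place of cyclobutyl on a carbonyl carbon).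

Within the data shown here, only one measured step involves a swap on a carbonyl carbon: (dimethylamino)methyl in place of 4-fluorophenyl gave a 2.1-fold higher number from compound 2 to compound 3 (0.33 log units; beyond the scatter), a modest change. That step replaced a ring with a chain, and it was made on compounds that differ elsewhere from compound 1. Among the measured compounds shown here, in the change to compound 4, one ring replaces another, and no measured pair shows such a swap. This single step therefore offers only weak guidance, and it gives no reason to expect a large shift. The expected change in this assay is small, an estimated 1.2-fold lower number from compound 1 to compound 4 (0.07 log units; within the scatter), which would not go beyond the scatter. For compound 4 the estimated value is 120 nM, with an expected range from 50 nM to 300 nM.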

Compound 4, half-maximal inhibitory concentration: > 5000 nM
Compound 4 ended at the assay's limit (the forecaster's own chance of this, stated with the estimate: 1%); middle value at least 41-fold (1.61 log units) away from the limit.
By their numbers in this assay, from the lowest: compounds 1 and 2 (each within the scatter of the next); then compound 3. At a limit, above all of these: compound 4.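

In this assay compound 4 gives > 5000 nM, which is a limit of the assay and not a number. Going by these compounds alone, exchanging one ring for another on this carbonyl carbon, whose other neighbour is an amide-type nitrogen, produced an at least 35-fold higher number from compound 1 to compound 4 (1.55 log units; beyond the scatter), far more than the only earlier step on a carbonyl carbon, a 2.1-fold higher number from compound 2 to compound 3 (0.33 log units; beyond the scatter), so in the setting of compound 1 activity here can depend strongly on which ring is attached. The true gap could be wider still, because the reading stops at the limit: the limit of > 5000 nM in this assay, at which 1 of the 4 values shown sits.

The change from cyclobutyl to furan-2-yl alters several things at once: the ring becomes aromatic, it gains a heavy atom, and it brings in an oxygen and a hydrogen-bond acceptor, so the compounds shown cannot say which of these goes with the loss. A cyclopentyl group on the same carbonyl carbon would add a ring atom without the oxygen or the aromatic ring, and a thiophen-2-yl group would keep a five-membered aromatic ring with sulfur in place of the oxygen, so the two would help pull these features apart.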